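This account rests on a few compounds, and the source may have more. Where it says the series, first, only, none or still open, it means among the compounds named here.

Working notes on the series. Compound 1 `CC1(c2cc(NC(=O)Cn3nnc(-c4ccccc4)n3)n(C3CCCCC3)n2)CC1` carries a cyclohexyl on the ring nitrogen and a methylcyclopropyl group on the core. In an assay on HEK293 cells for activation of Kir3.1/Kir3.2 (Homo sapiens), read by thallium flux (on this read-out higher numbers stand for an effect only at larger amounts of compound and lower numbers for an effect already at smaller amounts), compound 1 gives > 10000 nM, which is a limit of the assay and not a number. Compound 2 `Cc1cc(NC(=O)Cn2nnc(-c3ccccc3)n2)n(CC2CCCCC2)n1` gives 176 nM in this assay. Compound 3 `Cc1cc(NC(=O)Cn2nnc(-c3cccnc3)n2)n(C2CCCCC2)n1` gives 1930 nM in this assay. Among the two numbers shown, compound 3 stands highest; compound 2 gives the lower number, and the gap between the two is beyond the usual scatter of repeated measurements. Going by the values given here, no step between measured compounds that differ in one place is available, so the two values are reported as they stand and nothing is inferred from them about the ring nitrogen substituent or the aryl group on its own.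

Compound 4 `Cc1cc(NC(=O)Cn2nnc(-c3ccnc(F)c3)n2)n(C2CCCCC2)n1` is not yet measured. Relative to compound 3 it differs in one place: 2-fluoropyridin-4-yl in place of pyridin-3-yl on an aromatic carbon.

Among the compounds with values here, the expected step in this assay a 1.6-fold lower number from compound 3 to compound 4 (0.21 log units; within the scatter) is a modest move toward lower numbers, within or only slightly beyond the scatter, since no measured step bears on this exchange. The estimate for compound 4 in this assay is 1200 nM, with a range from 300 nM to 5000 nM.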

Compound 4, half-maximal effective concentration: 441 nM
Beside the measured number, compound 4's estimate is 2.7-fold (0.43 log units) above it; the range from low to high includes it.
By their numbers in this assay, from the lowest: compound 2; then compound 4; then compound 3. At a limit, above all of these: compound 1.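

On the aryl group of the five-membered aromatic ring with 4 nitrogen, the series now has its first comparison of compounds that differ in one place: in this assay, 2-fluoropyridin-4-yl in place of pyridin-3-yl gives a 4.4-fold lower number from compound 3 to compound 4 (0.64 log units; beyond the scatter), with the cyclohexyl and the methyl of the shared core unchanged. The result shows that this position can move the read-out beyond the scatter, even though the exchange keeps a six-membered aromatic ring with 1 hetero atom in place; the change is nevertheless double, with a different point of attachment of the ring and an added fluorine, so the step belongs to the whole group and not to either feature alone. Nothing among the data on hand bears on the reason for this step.

Still open, on these data alone, is whether the fluorine or the point of attachment carries the step, a question that unsubstituted pyridin-4-yl, or a methoxy group or an amine in place of the fluorine, would bear on. Also open, as far as these compounds go, is whether the step holds with the cyclohexylmethyl group of compound 2 on the ring nitrogen.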